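The source may report more compounds than this note shows. Statements on the series, on what has been measured and on what is new or still open speak of the compounds shown alone.

In a functional assay on SiHa cells (Homo sapiens) for antiproliferative activity, read by CCK-8 assay, with a stated time of 72 h (a lower number here means a stronger inhibitor, a higher number a weaker inhibitor), two compounds sharing one core have been measured so far. Compound 1 `COc1cc(-c2ncncc2-c2ccc(OCC(F)(F)F)cc2)cc(OC)c1OC` gives 33300 nM, and compound 2 `COc1cc(-c2ncncc2-c2ccc(Br)cc2)cc(OC)c1OC` gives 2960 nM, the lower of the two numbers and therefore the stronger result. These two differ in one place, with bromo in place of 2,2,2-trifluoroethoxy on an aromatic carbon, and the step is large: an 11-fold lower number from compound 1 to compound 2 (1.05 log units; beyond the scatter). Compound 3 `COc1cc(-c2ncncc2-c2ccc(B(O)O)cc2)cc(OC)c1OC` keeps the shared core and changes that same aromatic carbon, para to a large group: a group of 3 heavy atoms (1 boron, 2 oxygen; no ring) in place of one bromine atom, on an aromatic carbon. Unlike bromo, the entering group has hydrogen-bond donors and acceptors. Within the data shown here, the only measured step that bears on this change is an 11-fold lower number from compound 1 to compound 2 (1.05 log units; beyond the scatter), which shows that a swap at this carbon can shift the number in this assay substantially. Among the measured compounds shown here, no measured compound carries a group resembling the new one, so neither direction is firmly supported, and a wide range is needed. The expected change is small, a 1.4-fold higher number from compound 2 to compound 3 (0.13 log units; within the scatter), and this estimate is held loosely. Compound 3 is estimated at 4000 nM, with an expected range from 600 nM to 25000 nM.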

Compound 3, half-maximal inhibitory concentration: 17500 nM
Estimate against measurement, compound 3: 4.4-fold (0.64 log units) below, and the stated range covers the measured number.
By their numbers in this assay, from the lowest: compound 2; then compounds 3 and 1 (each within the scatter of the next).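

Putting the boron-and-oxygen group in place of bromo on this aromatic carbon weakens the result in this assay, with a 5.9-fold higher number from compound 2 to compound 3 (0.77 log units; beyond the scatter) as the step, which leaves compound 2 the strongest of the three. Two quite different replacements for bromo now sit close together, since a 1.9-fold lower number from compound 1 to compound 3 (0.28 log units; within the scatter) is a gap within the scatter, so these two cannot be ranked even though the entering group has 3 heavy atoms and carries hydrogen-bond donors. Within these three compounds, then, bromo is the group that stands apart at this position, and nothing measured here tells what lies behind that.

On these data alone, it remains open whether bromine itself matters or whether other small groups, such as chlorine, fluorine or methyl, would hold the number near that of compound 2. As far as these compounds go, it is also open whether an amine or a carboxylic acid on this carbon would fall with compound 3, and whether the trend would hold in other cell lines.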